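The source may hold more compounds than are shown below. What is called first, only, known or untested is meant among the compounds shown, and "the series" means these compounds.

Compound 1 `Brc1ccc(N(CC2CC2)C2=NCCN2)c(Br)c1` gives 11.2 in a physicochemical assay for acid dissociation.
Compound 2 `CCN(C1=NCCN1)c1c(Br)cccc1Br` gives 11.1 in this assay.
Compound 3 `CC(C)=CCN(C1=NCCN1)c1c(Br)cccc1Br` gives 10.8 in this assay.

All three compounds share the same core, a dibromophenyl ring whose nitrogen carries the imidazoline and a further group on a saturated chain carbon. Compound 3 has the lowest of the three numbers in this assay. Compound 2 sits closest to it, and the step of a number 0.30 log units lower from compound 2 to compound 3 (within the scatter) lies within the usual scatter of the measurement. Compound 1 gives a number a little further off, beyond the scatter.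

Compound 4 `Brc1cccc(Br)c1N(Cc1ccco1)C1=NCCN1` has not yet been measured. It differs from compound 3 only at that chain carbon: furan-2-yl in place of 2-methylprop-1-en-1-yl on a saturated chain carbon bound to a nitrogen on an aromatic ring. Going by the values given here, the one measured step at this place, a number 0.30 log units lower from compound 2 to compound 3 (within the scatter), shows that swapping methyl for 2-methylprop-1-en-1-yl there moved the number hardly at all. Among the compounds with values here, the data hold no step in which a furan-2-yl, or any aromatic ring, enters at this position, so the effect of the new group can only be guessed from the weak response seen so far. The expectation is a small shift, a number 0.20 log units lower from compound 3 to compound 4 (within the scatter), probably downward but not clearly beyond the scatter. Compound 4 is therefore estimated at 10.6, with a range from 10.1 to 11.1.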

Compound 4, acid dissociation constant: 10.5
Compound 4: the middle estimate sits 0.10 log units above what was measured, and the stated range covers the measured number.
By their numbers in this assay, from the lowest: compounds 4, 3, 2 and 1 (each within the scatter of the next, the first and the last beyond it).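

In this assay, furan-2-yl brings the first aromatic ring shown on a saturated chain carbon bound to a nitrogen on an aromatic ring, and replacing 2-methylprop-1-en-1-yl with it gives a number 0.30 log units lower from compound 3 to compound 4 (within the scatter), so this swap alone cannot be told apart from repeat-to-repeat variation. Going by these compounds alone, measured against methyl at the same place, however, furan-2-yl gives a number 0.60 log units lower from compound 2 to compound 4 (beyond the scatter), the first step here to clear the scatter, which shows that the number in this assay can respond to a change at this position, if only modestly. No measured information bears on why this shift occurs.

The compounds shown leave open whether a phenyl or thiophen-2-yl group at this place would give a number close to that of compound 4, a comparison that would show whether the furan oxygen matters or whether any aromatic ring would do. They also leave open how the number would respond to a longer saturated chain such as butyl, or to an amine or a carboxylic acid attached to this chain carbon.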